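This account rests on a few compounds, and the source may have more. Where it says the series, first, only, none or still open, it means among the compounds named here.

Measured so far in a functional assay on Venous blood for antagonist activity at C-X-C chemokine receptor type 3 (Homo sapiens), read by flow cytometry, with a stated time of 30 min, in the presence of a further agent that is not named here; on this read-out lower numbers stand for stronger inhibition and higher numbers for weaker inhibition:
- compound 1, `C[C@@H]1CN(c2sc(C(F)(F)F)nc2-c2nc3ccccc3[nH]2)CCN1C(=O)Cn1cccn1`: 191 nM
- compound 2, `C[C@@H]1CN(c2sc(C(F)(F)F)nc2-c2nc3ccccc3[nH]2)CCN1C(=O)Cn1cnc2c1CCN(C)C2`: 135 nM
- compound 3, `C[C@@H]1CN(c2sc(C(F)(F)F)nc2-c2nc3ccccc3[nH]2)CCN1C(=O)Cn1cc(C2CCN(C)CC2)cn1`: 1690 nM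

Compound 3 stands highest of the three numbers. The nearer value is that of compound 1, reached by an 8.8-fold higher number from compound 1 to compound 3 (0.95 log units; beyond the scatter); the further one is that of compound 2, reached by a 13-fold higher number from compound 2 to compound 3 (1.10 log units; beyond the scatter). Compound 1 and compound 2 lie within the scatter of each other, as a 1.4-fold lower number from compound 1 to compound 2 (0.15 log units; within the scatter) shows.

Compound 4, `COC1CCN(CC(=O)N2CCN(c3sc(C(F)(F)F)nc3-c3nc4ccccc4[nH]3)C[C@H]2C)C1`, is not yet measured. It differs from compound 3 in one place: 3-methoxypyrrolidin-1-yl in place of 4-(1-methylpiperidin-4-yl)-1H-pyrazol-1-yl on a saturated chain carbon bound to a carbonyl carbon. Both measured steps onto compound 3 bear on this: each added or enlarged a substituent on the saturated chain carbon bound to the carbonyl carbon and each raised the number beyond the scatter. Compound 4 removes the 4-(1-methylpiperidin-4-yl)-1H-pyrazol-1-yl group and brings in a smaller one, so the expectation is a step down in this assay of the same order, returning toward the range of compound 1 and compound 2, written as a 7.7-fold lower number from compound 3 to compound 4 (0.89 log units; beyond the scatter). Compound 4 is estimated at 220 nM, with a range of 80 nM to 650 nM.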

Compound 4, half-maximal inhibitory concentration: 3380 nM
The estimate for compound 4 lay 15-fold (1.19 log units) below the measured number; measured number outside the range, above it.
By their numbers in this assay, from the lowest: compounds 2 and 1 (each within the scatter of the next); then compounds 3 and 4 (each within the scatter of the next).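

In this assay, a smaller group on the saturated chain carbon bound to a carbonyl carbon does not by itself bring back the lower numbers: 3-methoxypyrrolidin-1-yl in place of 4-(1-methylpiperidin-4-yl)-1H-pyrazol-1-yl gives a 2.0-fold higher number from compound 3 to compound 4 (0.30 log units; within the scatter). The same group is well separated from the other two, with an 18-fold higher number from compound 1 to compound 4 (1.25 log units; beyond the scatter) and a 25-fold higher number from compound 2 to compound 4 (1.40 log units; beyond the scatter), so heavy-atom count does not order these groups: the group of compound 2 is larger than that of compound 4 yet has the lower number. The lowest two numbers belong to groups with a five-membered aromatic ring with 2 hetero atoms, but compound 3 carries that ring too and goes against any such rule.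

No measured evidence accounts for these differences. Open, on these data alone, is whether the methoxy matters, which plain pyrrolidin-1-yl or morpholin-4-yl at this place would address.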